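Changing the Cap Group on a Shared Core

A few compounds are considered here, and "the series" means these few. Any claim that something is new, unique, unknown or untested is made for them only; others in the source may bear on it.

Of the compounds shown here, two have been measured so far in a functional assay on PC-3 cells (Homo sapiens) for antiproliferative activity; a lower number here means a stronger inhibitor, a higher number a weaker inhibitor. Compound 1 `O=C(CCCCC[C@H](NC(=O)c1ccc(Br)cc1)C(=O)Nc1ccc(-c2ccccc2)cc1)NO` gives 531 nM in this assay. Compound 2 `CN(C)c1ccc(C(=O)N[C@@H](CCCCCC(=O)NO)C(=O)Nc2cccc3cccnc23)cc1` gives 220 nM in this assay, the lowest of the two numbers, and its gap to compound 1 lies beyond the usual scatter. Compound 3 `O=C(/C=C/c1ccccc1)N[C@@H](CCCCCC(=O)NO)C(=O)Nc1cccc2cccnc12` has not yet been measured. Its structure differs from compound 2 in one place: 2-phenylethenyl in place of 4-(dimethylamino)phenyl on a carbonyl carbon. Among the compounds with values here, no measured pair shows this exact change, so its effect cannot be read from a known step; the two values at hand only set the rough level where compound 3 should fall. The step of a 1.4-fold higher number from compound 2 to compound 3 (0.13 log units; within the scatter) is expected to be modest, leaning toward a slightly weaker inhibitor but possibly within the scatter. Compound 3 is therefore estimated to give 300 nM in this assay, with a range from 130 nM to 700 nM.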

Compound 3, half-maximal inhibitory concentration: 109 nM
The estimate for compound 3 lay 2.8-fold (0.44 log units) above the measured number; measured number below the stated range.
By their numbers in this assay, from the lowest: compounds 3 and 2 (each within the scatter of the next); then compound 1.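

On a carbonyl carbon of the shared core, putting 2-phenylethenyl in place of 4-(dimethylamino)phenyl gives a 2.0-fold lower number from compound 2 to compound 3 (0.30 log units; within the scatter) in this assay, so the two groups cannot be told apart by this read-out. The position therefore accepts a group without the nitrogen and hydrogen-bond acceptor of 4-(dimethylamino)phenyl, and with a double bond outside the aromatic ring, and the number stays within the scatter. No supporting measurement accounts for this result.

Still open, on these data alone, is whether 2-phenylethyl, which has a saturated link in place of the double bond, or a phenyl ring carrying a carboxylic acid would also stay at this level. The same pair of compounds also cannot tell whether this exchange would behave alike on a core with a different group on the other amide, such as the biphenyl-4-yl group of compound 1.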